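Aryl swap at the aromatic carbon: compound 3 outlook

The source may hold more compounds than are shown below. What is called first, only, known or untested is meant among the compounds shown, and "the series" means these compounds.

Measured so far:
compound 1, `CN(C)CCCCOC(=O)Nc1ccc(Cn2nc(-c3ccncc3)c3ccccc3c2=O)cc1` — 62700 nM
compound 2, `CN(C)CCCCOC(=O)Nc1ccc(Cn2nc(-c3ccc(C#N)cc3)c3ccccc3c2=O)cc1` — 37000 nM

In an ADME assay on Huh-7 cells (Homo sapiens) for cytotoxicity, read by MTT assay, with a stated time of 48 h (on this read-out higher numbers stand for lower toxicity in this test and lower numbers for higher toxicity in this test), compound 1 gives 62700 nM and compound 2 gives 37000 nM. Within the data shown here, the single measured step, a 1.7-fold lower number from compound 1 to compound 2 (0.23 log units; within the scatter), sits inside the scatter, so the two compounds cannot be ordered against each other. Compound 2 holds the lowest of the two numbers, but that rank carries no weight.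

Compound 3, `CN(C)CCCCOC(=O)Nc1ccc(Cn2nc(-c3cccc(F)c3)c3ccccc3c2=O)cc1`, differs from compound 2 in one place: 3-fluorophenyl in place of 4-cyanophenyl on an aromatic carbon. Among the measured compounds shown here, no measured step touches the 3-fluorophenyl group, and the only comparison at this position, the pyridin-4-yl to 4-cyanophenyl change, moved this assay by less than the scatter. With nothing else to go on, the working expectation for compound 3 is a number close to that of compound 2, with no step beyond the scatter in either direction.

On that basis compound 3 is expected to show 45000 nM in this assay, within a range from 20000 nM to 100000 nM, which corresponds to an expected step of a 1.2-fold higher number from compound 2 to compound 3 (0.09 log units; within the scatter).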

Compound 3, half-maximal cytotoxic concentration: 37400 nM
Compound 3: the middle estimate sits 1.2-fold (0.08 log units) above what was measured, within the range that was stated.
By their numbers in this assay, from the lowest: compounds 2, 3 and 1 (each within the scatter of the next).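

Notes on the aryl position: in this assay, 3-fluorophenyl in place of 4-cyanophenyl gives a 1.0-fold higher number from compound 2 to compound 3 (0.00 log units; within the scatter), and 3-fluorophenyl in place of pyridin-4-yl gives a 1.7-fold lower number from compound 1 to compound 3 (0.22 log units; within the scatter), so all three aryl groups at this aromatic carbon now lie within the scatter of one another. Compound 3 adds what compounds 1 and 2 did not cover: a carbon-only aromatic ring with no nitrile and no hydrogen-bond acceptor, carrying fluorine in its place, and with this change the read-out still does not separate the compounds. No supporting data bear on why the three numbers sit so close together.

Across these compounds the position has been explored only with six-membered aromatic rings, so it remains open whether a saturated ring such as morpholine, or a phenyl ring bearing a carboxylic acid or a primary amine, would give a step beyond the scatter. From the compounds shown here alone, the remainder of the structure is the same in all three compounds, so it also remains open how a shorter or longer chain in place of the four-carbon linker would read in this assay.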